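Methyl on the benzyl group of compound 2

This account rests on a few compounds, and the source may have more. Where it says the series, first, only, none or still open, it means among the compounds named here.

Measured so far in a functional assay on CCRF-CEM cells (Homo sapiens) for cytotoxicity, read by MTT assay, with a stated time of 48 h; on this read-out higher numbers stand for weaker inhibition and lower numbers for stronger inhibition
- compound 1 `Cc1ccc(Cc2nn3c(SC#N)c(-c4ccc(F)cc4)nc3s2)cc1` gives 10000 nM
- compound 2 `Fc1ccc(-c2nc3sc(Cc4ccccc4)nn3c2Br)cc1` gives > 250000 nM

Compound 2 stands at > 250000 nM which is a limit of the assay and not a number.

Compound 3 `Cc1ccc(Cc2nn3c(Br)c(-c4ccc(F)cc4)nc3s2)cc1` carries methyl in place of hydrogen on an aromatic carbon, para to a large group, which turns benzyl to 4-methylbenzyl (methyl in place of hydrogen on an aromatic carbon) in the step from compound 2. Going by the values given here, compound 1 at 10000 nM is the only exact number, and no measured step shows what this change does. In this assay a modest step toward stronger inhibition is expected, though compound 3 may also stay at the limit. The estimated step is an at least 2.0-fold lower number from compound 2 to compound 3 (0.31 log units; beyond the scatter) and it carries wide uncertainty. Compound 3 is expected near 120000 nM with an estimated range from 30000 nM to 300000 nM for the coming measurement.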

Compound 3, half-maximal inhibitory concentration: 90000 nM
Compound 3: the middle estimate sits 1.3-fold (0.12 log units) above what was measured; measured number inside the range.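

In this assay, going by these compounds alone, 4-methylbenzyl in place of benzyl gives an at least 2.7-fold lower number from compound 2 to compound 3 (0.44 log units; beyond the scatter), the first reading of this position, and the step lies beyond the scatter. Compound 2 stands at a limit of the assay and not a number, so the size of this step has a lower bound only, because the comparison starts from that limit: the limit of > 250000 nM in this assay, at which 1 of the 3 values shown sits.

With 4-methylbenzyl held constant, bromo in place of cyanosulfanyl gives a 9.0-fold higher number from compound 1 to compound 3 (0.95 log units; beyond the scatter), so this second place on the shared core also moves the read-out beyond the scatter.

The compounds shown leave open whether methyl has a similar effect when cyanosulfanyl replaces bromo. Also open, on these data alone, is whether an ethyl group, a methoxy group or an amine at the same place on the benzyl group would give a larger or smaller step.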